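Swapping the aryl group at the shared core

A few compounds are considered here, and "the series" means these few. Any claim that something is new, unique, unknown or untested is made for them only; others in the source may bear on it.

Two compounds share one core and differ only in the aryl group attached to it. Compound 1 `CCCS(=O)(=O)Nc1ccc(F)c(C(=O)c2n[nH]c3ncc(-c4cccc(F)c4)cc23)c1F` gives 8.2% in an assay for binding affinity to dual specificity mitogen-activated protein kinase kinase 4 (Homo sapiens), read by KINOMEscan, tested at 100 nM; a lower number here means a stronger effect, a higher number a weaker effect of the compound at the concentration tested. Compound 2 `CCCS(=O)(=O)Nc1ccc(F)c(C(=O)c2n[nH]c3ncc(-c4ccccc4C)cc23)c1F` gives 7% in the same test. Within the data shown here, of the two numbers, that of compound 2 is the lowest, with compound 1 nearest to it, and the two lie within the scatter of each other; the only step so far, a number 1.2 percentage points lower from compound 1 to compound 2 (within the scatter), is therefore one that shows no real change on swapping one aryl group for another at this carbon.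

Compound 3 `CCCS(=O)(=O)Nc1ccc(F)c(C(=O)c2n[nH]c3ncc(-c4ccc(OC)cc4)cc23)c1F` carries a further variation at the same place: 4-methoxyphenyl in place of 2-methylphenyl on an aromatic carbon. Among the measured compounds shown here, no step involving a methoxyphenyl group has been measured, so the single step from compound 1 to compound 2 is the only guide, and it was small. A step of about the same size, or none beyond the scatter, is therefore expected from compound 2 to compound 3 in this assay, as a number 2 percentage points higher from compound 2 to compound 3 (within the scatter). On this basis compound 3 is estimated to give 9%, with a likely range from 2% to 25%.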

Compound 3, a percentage reported as activity, at one concentration (the size of the read-out at that concentration, not a potency): 4.2%
Estimate against measurement, compound 3: 4.8 percentage points above; the range from low to high includes it.
By their numbers in this assay, from the lowest: compounds 3, 2 and 1 (each within the scatter of the next).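

Putting 4-methoxyphenyl at this carbon gives no real difference in this assay: the comparison with the 2-methylphenyl compound gives a number 2.8 percentage points lower from compound 2 to compound 3 (within the scatter), and the comparison with the 3-fluorophenyl compound gives a number 4 percentage points lower from compound 1 to compound 3 (within the scatter). All three compounds therefore lie within the scatter of one another, even though the phenyl ring carries its substituent at a different numbered position in each, and only 4-methoxyphenyl brings in an oxygen and a hydrogen-bond acceptor. Nothing available explains why these three aryl groups read alike in this test.

As far as these compounds go, it remains open whether the numbers stay this close once the phenyl ring itself gives way at this carbon, for example to a morpholine ring, a carboxylic acid or an open alkyl chain, or whether an amine on the phenyl ring would shift the read-out. Each value also comes from one concentration, so these numbers leave open whether compound 1, compound 2 and compound 3 would still show a like effect at other concentrations.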